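The source may hold more compounds than are shown below. What is called first, only, known or untested is meant among the compounds shown, and "the series" means these compounds.

Working notes on a small set of compounds sharing one core, all examined in an ADME assay on HEK293 cells for agonist activity at Toll-like receptor 8 (Homo sapiens), read by a luciferase reporter, with a stated time of 6 h; on this read-out higher numbers stand for an effect only at larger amounts of compound and lower numbers for an effect already at smaller amounts. Compound 1 `CC(C)CCNc1nc(N)nc2ccccc12` gives 2.11 uM in this assay. Compound 2 `CCCCNc1nc(N)nc2cc(CN(C)C)ccc12` gives 0.04 uM in this assay. Compound 3 `CCCCNc1nc(N)nc2ccc(OC)cc12` gives 1.8 uM in this assay. Compound 3 thus stands second highest of the three numbers; its nearest neighbour is compound 1, whose number lies within the scatter of it, while compound 2 lies far from it, beyond the scatter. Within the data shown here, no two measured compounds differ in only one place, so no measured step can serve as a guide.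

The next compound, compound 4 `CCCCNc1nc(N)nc2ccc(C#N)cc12`, differs from compound 3 as follows: cyano in place of methoxy on an aromatic carbon. Among the measured compounds shown here, no measured pair shows the same exchange, and the one large gap in the set, between compound 3 and compound 2, involves a different group at a different place and cannot be carried over. In this assay a modest step is expected, with no clear direction and possibly not beyond the scatter. The estimated step is a 1.5-fold lower number from compound 3 to compound 4 (0.18 log units; within the scatter). Compound 4 is expected to give about 1.2 uM in this assay, with a range from 0.35 uM to 4 uM.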

Compound 4, minimum effective concentration: 7.1 uM
Compound 4: middle estimate off by 5.9-fold (0.77 log units), on the low side; measured number above the stated range.
By their numbers in this assay, from the lowest: compound 2; then compounds 3 and 1 (each within the scatter of the next); then compound 4.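

Cyano in place of methoxy on this aromatic carbon gives a 3.9-fold higher number from compound 3 to compound 4 (0.60 log units; beyond the scatter) in this assay and provides the first measured step in the series that differs in one place. It shows that the group at this position, para to a fused ring and meta to a fused ring, can move the number beyond the scatter, with cyano requiring more compound for an effect than methoxy. The two groups have the same printed counts of heavy atoms and hydrogen-bond acceptors and carry no net charge, and nothing at hand explains the step.

On these data alone, whether a primary amine, a carboxylic acid or a chlorine atom at this carbon would give a lower or higher number remains open. As far as these compounds go, it also remains open whether the same exchange would give a similar step at another aromatic carbon of the shared core.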